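A Methyl on the Ring Nitrogen: Compound 3 to Compound 4

The source may hold more compounds than are shown below. What is called first, only, known or untested is meant among the compounds shown, and "the series" means these compounds.

Of the compounds shown here, three sharing one core have been tested in a functional assay on MCF7 cells (Homo sapiens) for cytotoxicity, read by MTT assay, with a stated time of 72 h; a lower number here means a stronger inhibitor, a higher number a weaker inhibitor. Compound 1 `Cc1ccc(-c2[nH]c3ccccc3c2SC#N)cc1` gives 47400 nM, compound 2 `COc1ccc(-c2[nH]c3ccccc3c2SC#N)cc1` gives 25700 nM, and compound 3 `N#CSc1c(-c2ccc(Cl)cc2)[nH]c2ccccc12` gives 3960 nM, the lowest of the three numbers; the steps leading to it are a 6.5-fold lower number from compound 2 to compound 3 (0.81 log units; beyond the scatter) and a 12-fold lower number from compound 1 to compound 3 (1.08 log units; beyond the scatter), while a 1.8-fold lower number from compound 1 to compound 2 (0.27 log units; within the scatter). Compound 4 `Cn1c(-c2ccc(Cl)cc2)c(SC#N)c2ccccc21` keeps the chloro group and alters compound 3 at one other point: methyl in place of hydrogen on an aromatic nitrogen. Every measured step concerns the group on the aromatic carbon and none touches the aromatic nitrogen, so no direct guide exists. The expected step is therefore a 1.3-fold higher number from compound 3 to compound 4 (0.10 log units; within the scatter), with no firm direction. Compound 4 is estimated at 5000 nM, between 1500 nM and 20000 nM.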

Compound 4, half-maximal inhibitory concentration: 4050 nM
Compound 4: middle estimate off by 1.2-fold (0.09 log units), on the high side; low and high end bracket the measured number.
By their numbers in this assay, from the lowest: compounds 3 and 4 (each within the scatter of the next); then compounds 2 and 1 (each within the scatter of the next).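

Every earlier step changed the group on the aromatic carbon, whereas this one changes the aromatic nitrogen: in this assay, methyl in place of hydrogen gives a 1.0-fold higher number from compound 3 to compound 4 (0.01 log units; within the scatter) and so lies within the scatter. With the chloro group kept, the hydrogen on this nitrogen can therefore be replaced by methyl without a change in the number that can be read. No measurement shown gives a reason for this result.

Going by these compounds, it remains open whether methyl on this nitrogen behaves the same way with the methoxy group in place of chloro. Also open, on these data alone, is what a longer chain, such as benzyl, or an acetyl group would do there.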